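The compounds below may be only part of what the source reports. "The series", "measured", "known", "first", "only" and "open" are said of these compounds alone.

Measured in a functional assay on A549 cells (Homo sapiens) for inhibition, read by MTT assay, with a stated time of 72 h; on this read-out lower numbers stand for stronger inhibition and higher numbers for weaker inhibition:
- compound 1 `COc1cc2c(Oc3ccc(NC(=O)c4nn(-c5ccccc5)cc(C)c4=O)cc3F)ccnc2cc1OCCCC(=O)NO`: 1900 nM
- compound 2 `COc1cc2c(Oc3ccc(NC(=O)c4nn(-c5ccccc5F)cc(C)c4=O)cc3F)ccnc2cc1OCCCC(=O)NO`: 1370 nM
- compound 3 `COc1cc2c(Oc3ccc(NC(=O)c4nn(-c5ccccc5F)cc(C)c4=O)cc3F)ccnc2cc1OCCCCCC(=O)NO`: 1320 nM

Compound 3 gives 1320 nM, and this value lies within the scatter of the other two, so the series is flat so far on this assay.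

The next compound is compound 4 `COc1cc2c(Oc3ccc(NC(=O)c4nn(-c5ccccc5)cc(C)c4=O)cc3F)ccnc2cc1OCCCCCC(=O)NO`, which has hydrogen in place of fluoro on an aromatic carbon. The closest evidence is a 1.4-fold lower number from compound 1 to compound 2 (0.14 log units; within the scatter), which is the same exchange run in the opposite direction on the other chain. The chain change itself, a 1.0-fold lower number from compound 2 to compound 3 (0.02 log units; within the scatter), also made no difference beyond the scatter. The fluoro exchange has been measured only once, so the read-across from that single pair is thin. On that basis, nothing beyond the scatter is expected for removal of the fluoro, and any drift should be toward a slightly higher number. The expected change is a 1.3-fold higher number from compound 3 to compound 4 (0.12 log units; within the scatter), which stays within the scatter. For compound 4 the estimated value is 1750 nM, with an expected range from 950 nM to 3200 nM.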

Compound 4, half-maximal inhibitory concentration: 4170 nM
Beside the measured number, compound 4's estimate is 2.4-fold (0.38 log units) below it; the measured number lies above the stated range.
By their numbers in this assay, from the lowest: compounds 3, 2 and 1 (each within the scatter of the next); then compound 4.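

In this assay, within the data shown here, both changes now give steps beyond the scatter where the earlier pairs did not: removing fluoro from the aromatic carbon ortho to a large group gives a 3.2-fold higher number from compound 3 to compound 4 (0.50 log units; beyond the scatter), and the chain change with phenyl in place of 2-fluorophenyl gives a 2.2-fold higher number from compound 1 to compound 4 (0.34 log units; beyond the scatter). The fluoro exchange still cannot be said to differ in size between the two chains: the same change on two cores in this assay, a 1.4-fold lower number (0.14 log units; within the scatter) from compound 1 to compound 2 and a 3.2-fold lower number (0.50 log units; beyond the scatter) from compound 4 to compound 3, 2.3-fold (0.36 log units) apart, within the scatter of two such steps. The same holds for the chain change with and without the fluoro: the same change on two cores in this assay, a 1.0-fold lower number (0.02 log units; within the scatter) from compound 2 to compound 3 and a 2.2-fold higher number (0.34 log units; beyond the scatter) from compound 1 to compound 4, 2.3-fold (0.36 log units) apart, within the scatter of two such steps.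

Open, on these data alone, is whether chloro or methyl on that aromatic carbon would give a number like that of compound 3 or one like that of compound 4. Also open, as far as these compounds go, is how a longer chain would read with 2-fluorophenyl and with phenyl.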